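The source may report more compounds than this note shows. Statements on the series, on what has been measured and on what is new or still open speak of the compounds shown alone.

Compound 2 `Cc1c(Oc2ccccc2OCCn2ccc(=O)[nH]c2=O)cc(Cl)c2ccc(C#N)cc12` is the starting point of this step. In a toxicity assay on MT2 cells (Homo sapiens) for cytotoxicity, read by MTT assay (a lower number here means that less compound is tolerated, a higher number that more compound is tolerated), compound 2 reaches only a limit, > 100000 nM, so for this compound there is no number but a boundary of the measurement, as the evidence notes (the limit of > 100000 nM in this assay, at which 1 of the 3 values shown sits). The two compounds with numbers set the frame. Compound 1 `N#Cc1cc2c(Oc3ccc(F)cc3OCCn3ccc(=O)[nH]c3=O)cc(F)cn2c1` gives 50000 nM in this assay. Compound 3 `Cc1c(Oc2ccccc2OCCn2ccc(=O)[nH]c2=O)cc(CC2CC2)c2ccc(C#N)cc12` gives 13000 nM in this assay.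

Compound 4 `COCc1cc(Oc2ccccc2OCCn2ccc(=O)[nH]c2=O)c(C)c2cc(C#N)ccc12` differs from compound 2 in one place: methoxymethyl in place of chloro on an aromatic carbon.

For the measured compounds named here, only one measured step bears on this change, the one from compound 2 to compound 3, where cyclopropylmethyl replaces chloro on the same aromatic carbon, an at least 7.6-fold lower number from compound 2 to compound 3 (0.88 log units; beyond the scatter). Compound 4 puts methoxymethyl rather than cyclopropylmethyl at that carbon, so the carbon-for-chloro exchange is shared while the group itself is not the same. On that basis a step downward from the limit of compound 2 is expected for compound 4 in this assay, though its size is uncertain, and it may stay at the limit.

The expected step from compound 2 to compound 4 is an at least 2.5-fold lower number from compound 2 to compound 4 (0.39 log units; beyond the scatter). Compound 4 is therefore estimated at 40000 nM in this assay, within a range from 12000 nM to 100000 nM.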

Compound 4, half-maximal cytotoxic concentration: 16000 nM
Estimate against measurement, compound 4: 2.5-fold (0.40 log units) above; the range from low to high includes it.
By their numbers in this assay, from the lowest: compounds 3 and 4 (each within the scatter of the next); then compound 1. At a limit, above all of these: compound 2.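

In this assay, a second group put in place of chloro on this aromatic carbon also brings the number down, with an at least 6.2-fold lower number from compound 2 to compound 4 (0.79 log units; beyond the scatter), so the drop now holds for both methoxymethyl and cyclopropylmethyl and does not rest on one group alone. Both steps start from a boundary of the measurement and not from a number, and the boundary belongs to compound 2: the limit of > 100000 nM in this assay, at which 1 of the 4 values shown sits. The two groups are not told apart here, with a 1.2-fold higher number from compound 3 to compound 4 (0.09 log units; within the scatter), which lies within the scatter, so methoxy in place of cyclopropyl at the end of the chain leaves no readable change in how much compound is tolerated.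

On these data alone, whether a plain methyl, an amine, a carboxylic acid or a longer chain on this carbon would sit with compound 3 and compound 4 or stay with compound 2 remains open. As far as these compounds go, it is also open whether the drop follows from the loss of chloro or from the chain that enters, and the full size of either step from compound 2 cannot be fixed while its start is a limit.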